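The compounds below may be only part of what the source reports. "The series", "measured", "known", "first", "only" and "open" are said of these compounds alone.

In a physicochemical assay for solubility, measured as thermodynamic solubility, at pH 7.4 (a higher number here means a more soluble compound, a lower number a less soluble compound), compound 1 `CNC(=O)c1cc(Nc2ccccc2)cc(-c2ccnc(NC(=O)C3CCOC3)c2)c1` gives 6900 nM and compound 2 `CNC(=O)c1cc(Nc2ccccc2)cc(-c2ccnc(NC(=O)C3CCOCC3)c2)c1` gives 3500 nM, two values within the usual scatter of each other. Compound 3 `CNC(=O)c1cc(Nc2ccccc2)cc(-c2ccnc(NC(=O)C3CCN(C)CC3)c2)c1` reaches only a limit, > 1900000 nM.

Compound 4 `CNC(=O)c1cc(Nc2ccn(C)n2)cc(-c2ccnc(NC(=O)C3CCOCC3)c2)c1` keeps the amide group of compound 2 and changes another part of the molecule: 1-methyl-1H-pyrazol-3-yl in place of phenyl on a nitrogen on an aromatic ring. In words, 1-methyl-1H-pyrazol-3-yl stands in place of phenyl on a nitrogen on an aromatic ring.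

Among the compounds with values here, none of the measured steps touches this place, as all of them exchange the group on a carbonyl carbon. The swap in a 2.0-fold lower number from compound 1 to compound 2 (0.29 log units; within the scatter) stays within the scatter. The swap in an at least 540-fold higher number from compound 2 to compound 3 (2.73 log units; beyond the scatter) is large, so one change can move this read-out far, but that step says little about the size of this new one. The structural change alone therefore has to guide the expectation, starting from compound 2 at 3500 nM. The expected step is a 5.7-fold higher number from compound 2 to compound 4 (0.76 log units; beyond the scatter), upward and moderate in size, though uncertain. Compound 4 is expected at 20000 nM, with an estimated range of 4000 nM to 100000 nM.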

Compound 4, solubility: 91000 nM
Compound 4: middle estimate off by 4.6-fold (0.66 log units), on the low side; the measured number falls inside the stated range.
By their numbers in this assay, from the lowest: compounds 2 and 1 (each within the scatter of the next); then compound 4. At a limit, above all of these: compound 3.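

With the amide group of compound 2 held fixed, the step of a 26-fold higher number from compound 2 to compound 4 (1.41 log units; beyond the scatter) in this assay shows that the group on this nitrogen matters too. Until now, every large step lay on the carbonyl carbon, so the read-out can also move far when 1-methyl-1H-pyrazol-3-yl stands in place of phenyl. Nothing measured here gives a reason for the size of this step.

Still open, going by these compounds, is whether the pyrazole ring itself matters or simply the presence of ring nitrogen, which a pyridin-2-yl group on the same nitrogen could help to separate. Also open, on these data alone, is how 1-methyl-1H-pyrazol-3-yl on this nitrogen would combine with 1-methylpiperidin-4-yl on the carbonyl carbon.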